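Replacing Nitro with Chloro in a Growth Inhibitor

The compounds below may be only part of what the source reports. "The series", "measured", "known", "first", "only" and "open" are said of these compounds alone.

In a functional assay on HCT-116 cells (Homo sapiens) for inhibition, read by MTT assay, with a stated time of 2 days (on this read-out higher numbers stand for weaker inhibition of growth and lower numbers for stronger inhibition of growth), compound 1 `Nc1ccccc1NC(=O)CCCNCC(=O)Nc1ccc(Cl)cc1` gives 45000 nM as its reading. Compound 2 `Nc1ccccc1NC(=O)c1ccc(NCC(=O)Nc2ccc([N+](=O)[O-])cc2)cc1` gives 6500 nM and so holds the lower of the two numbers, a gap beyond the usual scatter of repeat measurements. That makes compound 2 the stronger inhibitor of growth of this pair.

Compound 3 `Nc1ccccc1NC(=O)c1ccc(NCC(=O)Nc2ccc(Cl)cc2)cc1` has not yet been measured. It differs from compound 2 in one place, with chloro in place of nitro on an aromatic carbon, para to a large group chloro in place of nitro on an aromatic carbon in the count of atoms. Among the compounds with values here, no measured pair here shows what this exchange does, so the expectation in this assay is for no step beyond the scatter, in neither direction. The estimated change is a 1.2-fold higher number from compound 2 to compound 3 (0.09 log units; within the scatter) and it stays small. Compound 3 is expected to read about 8000 nM with an estimated range from 3000 nM to 20000 nM in this test.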

Compound 3, concentration for total growth inhibition: 62500 nM
Estimate against measurement, compound 3: 7.8-fold (0.89 log units) below, and the stated range ends below it.
By their numbers in this assay, from the lowest: compound 2; then compounds 1 and 3 (each within the scatter of the next).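

In this assay, within the data shown here, putting chloro in place of nitro on this aromatic carbon gives a 9.6-fold higher number from compound 2 to compound 3 (0.98 log units; beyond the scatter), the first measured reading of this exchange. The position, para to a large group, therefore does not accept both groups alike: with the rest of the structure unchanged, this single exchange separates the stronger inhibitor of growth from a weaker one. Nothing shown here speaks to why the two groups differ.

As far as these compounds go, only one replacement for nitro appears at this position, so it remains open how a nitrile, an amine, a carboxylic acid or a plain hydrogen in the same place would read. From the compounds shown here alone, it also remains open whether the same exchange would give a step of similar size on the core of compound 1, which carries a chain in place of the central ring.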